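Piperazine nitrogen swap in a thiocarbamate amide series

The compounds below may be only part of what the source reports. "The series", "measured", "known", "first", "only" and "open" are said of these compounds alone.

Measured so far in a functional assay on A-375 cells (Homo sapiens) for antiproliferative activity, read by CCK-8 assay, with a stated time of 72 h, tested at 8 uM; on this read-out higher numbers stand for a stronger effect at the one concentration tested and lower numbers for a weaker effect:
compound 1 `Nc1ccccc1NC(=O)c1ccc(CSC(=S)N2CCN(c3ccccc3)CC2)cc1`, 88.6%
compound 2 `Nc1ccccc1NC(=O)c1ccc(CSC(=S)N2CCCc3ccccc32)cc1`, 81.5%
compound 3 `CC1CCCCN1C(=S)SCc1ccc(C(=O)Nc2ccccc2N)cc1`, 85.2%

Compound 1 gives the highest of the three numbers, but its gaps to compound 3 and to compound 2 both lie within the scatter, so no order among the three can be claimed. Within the data shown here, the only step between neighbours, a number 3.7 percentage points higher from compound 2 to compound 3 (within the scatter), exchanges the whole amine ring and likewise stays within the scatter.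

Compound 4 `Nc1ccccc1NC(=O)c1ccc(CSC(=S)N2CCN(Cc3cccnc3)CC2)cc1` differs from compound 1 as follows: (pyridin-3-yl)methyl in place of phenyl on an amine nitrogen in a ring. Among the measured compounds shown here, no measured step alters a substituent on the ring nitrogen, so nothing bears on it directly; the one step seen was flat. A step of a number 4.6 percentage points lower from compound 1 to compound 4 (within the scatter) is therefore expected, none beyond the scatter. Compound 4 is estimated at 84%, between 70% and 95%.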

Compound 4, a percentage reported as inhibition, at one concentration (the size of the read-out at that concentration, not a potency): 89.2%
For compound 4 the middle estimate is 5.2 percentage points below the measured one, within the range that was stated.
By their numbers in this assay, from the lowest: compounds 2, 3, 1 and 4 (each within the scatter of the next).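

In this assay, among these compounds, the substituent on the amine nitrogen in a ring is changed for the first time, and (pyridin-3-yl)methyl in place of phenyl gives a number 0.6 percentage points higher from compound 1 to compound 4 (within the scatter) with the rest of the structure unchanged. At this position, a one-atom larger group with one hydrogen-bond acceptor therefore leaves the read-out within the scatter of the phenyl compound. No measured evidence explains this flat step.

From the compounds shown here alone, whether a carboxylic acid or a longer alkyl chain on this nitrogen would shift the number stays open. A single concentration also leaves any difference in potency between compound 1 and compound 4 unresolved.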